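Clearance notes: compound 3 to the 3-propoxyphenyl compound 4

A few compounds are considered here, and "the series" means these few. Any claim that something is new, unique, unknown or untested is made for them only; others in the source may bear on it.

Within the data shown here, in an in vitro ADME assay on microsomes from liver (Homo sapiens) for metabolic stability, using NADPH (on this read-out lower numbers stand for slow clearance and higher numbers for fast clearance), compound 3 (`Cc1ccc(C)c(Cn2c(C(=O)NCC(C)(C)CO)cc3cc(C#N)ccc32)c1`) gives 257 mL.min-1.g-1, the highest of the three numbers so far. Compound 2 (`Cc1ccc(Cl)cc1Cn1c(C(=O)NCC(C)(C)CO)cc2cc(C#N)ccc21`) gives 119 mL.min-1.g-1, and compound 1 (`CC(C)(CO)CNC(=O)c1cc2cc(C#N)ccc2n1Cc1cccc(OC(F)(F)F)c1`) gives 62 mL.min-1.g-1. All three share the core and the amide chain of compound 4 (`CCCOc1cccc(Cn2c(C(=O)NCC(C)(C)CO)cc3cc(C#N)ccc32)c1`), which has not yet been measured.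

The change from compound 3 to compound 4 is 3-propoxyphenyl in place of 2,5-dimethylphenyl on a saturated chain carbon bound to an aromatic nitrogen.

Among the measured compounds shown here, only one measured step bears on this: a 2.2-fold higher number from compound 2 to compound 3 (0.33 log units; beyond the scatter), with methyl in place of chloro on an aromatic carbon. It is modest, and it alters a single substituent, whereas the new change replaces the whole group, so it offers only a weak guide. For the measured compounds named here, no propoxy compound has been measured. Going by the values given here, the span from compound 1 at 62 mL.min-1.g-1 to compound 3 at 257 mL.min-1.g-1 leaves room for a lower number, while compound 3 sits at the top of the series so far. A small fall that stays inside the usual scatter is therefore the working expectation, with a wide range.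

The expected step is a 1.4-fold lower number from compound 3 to compound 4 (0.13 log units; within the scatter). For compound 4 the estimated value is 190 mL.min-1.g-1, with an expected range of 85 mL.min-1.g-1 to 400 mL.min-1.g-1.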

Compound 4, intrinsic clearance in microsomes: 156 mL.min-1.g-1
Compound 4: the middle estimate sits 1.2-fold (0.09 log units) above what was measured, and the stated range covers the measured number.
By their numbers in this assay, from the lowest: compounds 1, 2, 4 and 3 (each within the scatter of the next, the first and the last beyond it).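

In this assay the whole group on a saturated chain carbon bound to an aromatic nitrogen can be exchanged without a step beyond the scatter: replacing 2,5-dimethylphenyl with 3-propoxyphenyl gives a 1.6-fold lower number from compound 3 to compound 4 (0.22 log units; within the scatter) and replacing 5-chloro-2-methylphenyl with it gives a 1.3-fold higher number from compound 2 to compound 4 (0.12 log units; within the scatter) in these notes. Among these compounds, the substituent on the oxygen is a different matter, since propyl in place of trifluoromethyl gives a 2.5-fold higher number from compound 1 to compound 4 (0.40 log units; beyond the scatter) and this is the only one of the new steps that lies beyond the scatter, showing that within this pair of ethers the group on the oxygen changes the clearance number. No measurement at hand accounts for any of these steps.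

Open, going by these compounds, is how the number runs with the group on that oxygen between trifluoromethyl and propyl, for instance with methyl, ethyl or a longer chain such as butyl. Also open, on these data alone, is whether an amine or a carboxylic acid at the end of the propyl chain would bring compound 4 closer to compound 1 in this read-out.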